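This account rests on a few compounds, and the source may have more. Where it says the series, first, only, none or still open, it means among the compounds named here.

Measured in a functional assay on HCT-116 cells (Homo sapiens) for inhibition, read by colorimetric assay, with a stated time of 3 days; a higher number here means a weaker inhibitor, a lower number a stronger inhibitor:
- compound 1 `COc1ccc(NC(=O)CCCCCCNC(=O)C(O)(O)C(F)(F)F)cc1`: 4520 nM
- compound 2 `O=C(CCCCCCNC(=O)C(O)(O)C(F)(F)F)Nc1ccccc1`: 9140 nM
- compound 3 `CC(=O)c1ccc(NC(=O)CCCCCCNC(=O)C(O)(O)C(F)(F)F)cc1`: 12100 nM

Not yet measured: compound 4 `O=C(CCCCCCNC(=O)C(O)(O)C(F)(F)F)Nc1ccc(-c2ccccc2)cc1`.

Compound 3 stands at the high-number end of this small set, level with its nearest neighbour within the scatter: a 1.3-fold higher number from compound 2 to compound 3 (0.12 log units; within the scatter). The furthest measured gap is a 2.7-fold higher number from compound 1 to compound 3 (0.43 log units; beyond the scatter).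

The next change is phenyl in place of acetyl on an aromatic carbon, para to a large group. Three measured steps at this same aromatic carbon bear on it. Besides the two above, there is a 2.0-fold higher number from compound 1 to compound 2 (0.31 log units; beyond the scatter). All are modest or within the scatter, but none brings in a ring, so the data give only a loose guide. A modest step in this assay is expected, towards a lower number, as compound 1 at 4520 nM shows that replacing acetyl at this carbon can lower the number. The expected change is a 2.0-fold lower number from compound 3 to compound 4 (0.30 log units; within the scatter). The estimate for compound 4 is 6000 nM, with an expected range of 2000 nM to 15000 nM.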

Compound 4, half-maximal inhibitory concentration: 4730 nM
The estimate for compound 4 lay 1.3-fold (0.10 log units) above the measured number; the measured number falls inside the stated range.
By their numbers in this assay, from the lowest: compounds 1, 4, 2 and 3 (each within the scatter of the next, the first and the last beyond it).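

At this aromatic carbon, para to a large group, this assay now shows that an added aromatic ring is compatible with a number at the low end of the set, with a 2.6-fold lower number from compound 3 to compound 4 (0.41 log units; beyond the scatter). Against the smaller groups at the same carbon, the phenyl change cannot be separated from the scatter: there is a 1.9-fold lower number from compound 2 to compound 4 (0.29 log units; within the scatter), and a 1.0-fold higher number from compound 1 to compound 4 (0.02 log units; within the scatter), so among these four compounds only acetyl stands apart from methoxy and from phenyl. No accompanying measurement bears on what lies behind these differences.

Still open, on these data alone, is whether phenyl bearing an amine or a carboxylic acid, or a saturated cyclohexyl ring, would hold the number at this level. Also open, as far as these compounds go, is whether a longer chain in the shared core would alter the ranking of these groups.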